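The source may hold more compounds than are shown below. What is called first, only, known or untested is meant among the compounds shown, and "the series" means these compounds.

Compound 2 `CNC(=O)c1cc(C(=O)NC2CC2)cn(CC2CCOCC2)c1=O` stands at a limit in a physicochemical assay for solubility; a lower number here means a less soluble compound, a higher number a more soluble compound: its reading there, >= 165 ug/mL, is a limit of the assay rather than a number. The two other measured compounds stand the same way. For compound 1 `CNC(=O)c1cc(C(=O)NCCCC2CNCCO2)cn(Cc2ccccc2)c1=O` the reading >= 194 ug/mL is likewise a limit. For compound 3 `CNC(=O)c1cc(C(=O)NC2CC2)cn([C@H](C)c2ccccc2)c1=O` the reading >= 168 ug/mL is a limit as well. For the measured compounds named here, the single step between measured compounds that differ in one place, a step that the two limits leave unreadable from compound 2 to compound 3, therefore cannot be read, as the limit of >= 165 ug/mL in this assay, at which 1 of the 3 values shown sits, and the limit of >= 168 ug/mL in this assay, at which 1 of the 3 values shown sits, show. Compound 4 `CNC(=O)c1cc(C(=O)NC2CC2)cn(Cc2cccc(C#N)c2)c1=O` differs from compound 2 in one place: 3-cyanophenyl in place of oxan-4-yl on a saturated chain carbon bound to an aromatic nitrogen. Going by the values given here, no measured step bears directly on this change; the nearest comparison is compound 3, whose 1-phenylethyl group also carries a six-membered aromatic ring of carbon only, and it too sits at a limit, (the limit of >= 168 ug/mL in this assay, at which 1 of the 3 values shown sits). Compound 4 is therefore expected to stay near the limit as well, with a step of an at least 1.3-fold lower number from compound 2 to compound 4 (0.13 log units; that floor lies within the scatter) that is estimated to be small and, if anything, toward lower solubility. The value of compound 4 in this assay is estimated at 120 ug/mL, within a range from 40 ug/mL to 250 ug/mL.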

Compound 4, solubility: >= 148 ug/mL
Compound 4 gave a limit, no number; the forecaster's own chance of this, stated with the estimate: 40%; middle value at least 1.2-fold (0.09 log units) away from the limit.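

Compound 4 reads >= 148 ug/mL in this assay, which is a limit and not a number. Compound 2 also stands at a limit, so the step between compound 2 and compound 4 cannot be read. All four readings are limits, which leaves open how large any difference among these compounds in this assay is.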